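This account rests on a few compounds, and the source may have more. Where it says the series, first, only, none or still open, it means among the compounds named here.

Two compounds built on a shared core have so far been run in an ADME assay (liver) for metabolic stability, with Liver microsome (Rattus norvegicus) as the target, read by LC-MS, using microsomes, with a stated time of 30 min, tested at 4 uM; on this read-out higher numbers stand for a more stable compound and lower numbers for a less stable compound. Compound 1, `CCN1CCN(c2nc(C)nc3c2nc(-c2ccccc2Cl)n3C)CC1`, gives 30%. Compound 2, `Cc1nc(N2CCN(C)CC2)c2nc(-c3cccc(Cl)c3)n(C3CCOCC3)c2n1`, gives 45%, the higher of the two numbers, and its gap to compound 1 lies beyond the usual scatter of this kind of measurement. Compound 3, `CCc1ccccc1-c1nc2c(N3CCN(C)CC3)nc(C)nc2n1C1CCOCC1`, has not yet been tested in this assay. It differs from compound 2 in a single place: 2-ethylphenyl in place of 3-chlorophenyl on an aromatic carbon. Going by the values given here, no pair of measured compounds differs in this same way, so the size of such a step cannot be read from the numbers in hand. A moderate fall in this assay is expected, although an outcome within the scatter of compound 2 cannot be ruled out. The expected step is a number 10 percentage points lower from compound 2 to compound 3 (within the scatter). Compound 3 is therefore estimated to give 35%, with a likely range from 15% to 58%.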

Compound 3, percent of the compound remaining: 51%
The estimate for compound 3 lay 16 percentage points below the measured number; the range from low to high includes it.
By their numbers in this assay, from the lowest: compound 1; then compounds 2 and 3 (each within the scatter of the next).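

In this assay, placing 2-ethylphenyl instead of 3-chlorophenyl on this aromatic carbon gives a number 6 percentage points higher from compound 2 to compound 3 (within the scatter). This position therefore accepts a phenyl ring carrying an ethyl group instead of a chlorine, with the group at a different place on that ring, and the reading cannot be told apart from that of compound 2. Nothing available explains this outcome.

The change alters both the group on the phenyl ring and its place there, and compound 2 and compound 3 alone cannot separate these two differences. From the compounds shown here alone, it also remains open whether 3-ethylphenyl, or a phenyl ring bearing an amine or a carboxylic acid, would read alike on this same carbon.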